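Swapping an Indolyl Ring for a Halogenated Phenyl

This account rests on a few compounds, and the source may have more. Where it says the series, first, only, none or still open, it means among the compounds named here.

Three compounds carry a measurement in a functional assay on J774 cells (Mus musculus) for cytotoxicity, read by resazurin assay, with a stated time of 72 h; a higher number here means a weaker inhibitor, a lower number a stronger inhibitor. Compound 1 `O=S(=O)(Nc1ccc(CO)c(CO)c1)c1ccc(-c2ccc(F)cc2)cc1` gives 1000 nM. Compound 2 `O=S(=O)(Nc1ccc(CO)c(CO)c1)c1ccc(-c2ccc(F)cc2F)cc1` differs from compound 1 by a fluoro in place of hydrogen on an aromatic carbon; compound 2 gives 150 nM, and the step of a 6.7-fold lower number from compound 1 to compound 2 (0.82 log units; beyond the scatter) lies beyond the scatter. Compound 3 `O=S(=O)(Nc1cccc(CO)c1)c1ccc(-c2ccc3[nH]ccc3c2)cc1` is the weakest case among the three, and in this assay compound 3 returns only a limit, > 5000 nM. That limit is the one described by the limit of > 5000 nM in this assay, at which 1 of the 3 values shown sits.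

Compound 4 `O=S(=O)(Nc1cccc(CO)c1)c1ccc(-c2ccc(Cl)cc2F)cc1` is not yet measured in this assay. It differs from compound 3 in one place: 4-chloro-2-fluorophenyl in place of 1H-indol-5-yl on an aromatic carbon. Going by the values given here, no measured step mirrors this change exactly; the closest guide is the step from compound 1 to compound 2, where adding a fluoro to the phenyl ring gave the modest 6.7-fold lower number from compound 1 to compound 2 (0.82 log units; beyond the scatter). Among the compounds with values here, compound 4 also carries a chloro that no measured compound shares, and its core is that of compound 3 rather than of compounds 1 and 2. Since compound 3 stands only at a limit, the expected step of an at least 3.3-fold lower number from compound 3 to compound 4 (0.52 log units; beyond the scatter) can be judged only as moving toward a lower number. Compound 4 is therefore estimated at 1500 nM, within a range from 300 nM to 5000 nM.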

Compound 4, half-maximal inhibitory concentration: 700 nM
The estimate for compound 4 lay 2.1-fold (0.33 log units) above the measured number; the measured number falls inside the stated range.
By their numbers in this assay, from the lowest: compound 2; then compounds 4 and 1 (each within the scatter of the next). At a limit, above all of these: compound 3.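

The swap of 1H-indol-5-yl for 4-chloro-2-fluorophenyl gives an at least 7.1-fold lower number from compound 3 to compound 4 (0.85 log units; beyond the scatter) in this assay, the first step shown on this core and the first to reach this position, on an aromatic carbon para to a large group. Until now the core of compound 3 had offered no number at all, and the earlier step had shown only a fluoro added to a phenyl ring on a different core, so the result extends the effect of the group at this position to a full exchange of the ring system. The true size of the step stays unknown because compound 3 gives only a limit, so the step is a floor: the limit of > 5000 nM in this assay, at which 1 of the 4 values shown sits.

The exchange removes the five-membered ring and its hydrogen-bond donor and brings in both fluorine and chlorine at once, so the compounds shown cannot say which of these parts carries the step. They also leave open how this position would respond to a phenyl bearing an amine or a carboxylic acid, or to 4-chloro-2-fluorophenyl on the core of compound 1.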